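Chloro for Methoxy on a Weak Kinase Inhibitor

This account rests on a few compounds, and the source may have more. Where it says the series, first, only, none or still open, it means among the compounds named here.

Compound 2 `COc1ccc(Nc2nccc(-c3c(C)[nH]c4ccc(OC)cc34)n2)cc1` is the weaker of the two compounds tested in an assay on isolated protein for inhibition of interferon-induced, double-stranded RNA-activated protein kinase (Homo sapiens), read by luminescence, with a stated time of 10 min; on this read-out higher numbers stand for weaker inhibition and lower numbers for stronger inhibition: compound 2 gives 55000 nM, while compound 1 `CN1CCN(c2ccc(Nc3ncnc4ccc([N+](=O)[O-])cc34)cc2)CC1` gives 15000 nM, a gap beyond the usual scatter. Compound 3 `COc1ccc2[nH]c(C)c(-c3ccnc(Nc4ccc(Cl)cc4)n3)c2c1` differs from compound 2 in one place, (chloro in place of methoxy on an aromatic carbon), on an aromatic carbon of a six-membered aromatic ring of carbon only, para to a large group. Within the data shown here, no measured pair shows this exchange, so no change beyond the scatter is expected in this assay. For compound 3 the estimated value in this assay is 40000 nM, between 15000 nM and 100000 nM. The expected step of a 1.4-fold lower number from compound 2 to compound 3 (0.14 log units; within the scatter) is small.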

Compound 3, half-maximal inhibitory concentration: 50000 nM
Beside the measured number, compound 3's estimate is 1.3-fold (0.10 log units) below it, within the range that was stated.
By their numbers in this assay, from the lowest: compound 1; then compounds 3 and 2 (each within the scatter of the next).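

In this assay, among these compounds, chloro in place of methoxy on an aromatic carbon para to a large group gives a 1.1-fold lower number from compound 2 to compound 3 (0.04 log units; within the scatter) and so offers the first measured reading of this exchange: compound 2 and compound 3 cannot be told apart. The methoxy group counts one hydrogen-bond acceptor and the chloro group none, yet this difference does not appear in the numbers. Nothing available speaks to the reason for this result. The compounds shown leave open what an amine or a carboxylic acid would give at this position. They also leave open whether any group there would move the number beyond the scatter.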